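From (3-hydroxypropyl)amino to bis(2-hydroxyethyl)amino

The source may report more compounds than this note shows. Statements on the series, on what has been measured and on what is new or still open speak of the compounds shown alone.

In a functional assay on SW-620 cells (Homo sapiens) (a lower number here means a stronger inhibitor, a higher number a weaker inhibitor), compound 1 (`COc1cc(NC(C)CCCNC(=O)NCCO)c2ncccc2c1`) gives > 100000 nM, which is a limit and not a number. Compound 2 (`COc1cc(NC(C)CCCNC(=O)NCCCO)c2ncccc2c1`) gives > 100000 nM, also only a limit, and so stands at the limit of > 100000 nM in this assay, at which 2 of the 3 values shown sit. Compound 3 (`COc1cc(NC(C)CCCNC(=O)NOCc2ccccc2)c2ncccc2c1`) gives a real number, 20000 nM.

Compound 4 (`COc1cc(NC(C)CCCNC(=O)N(CCO)CCO)c2ncccc2c1`) is still unmeasured. It carries bis(2-hydroxyethyl)amino in place of (3-hydroxypropyl)amino on a carbonyl carbon.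

Within the data shown here, three measured steps bear on this change. The closest is a step that the two limits leave unreadable from compound 1 to compound 2, which gives no size. Among the measured compounds shown here, the only readable steps are an at least 5.0-fold lower number from compound 1 to compound 3 (0.69 log units; beyond the scatter) and an at least 5.0-fold lower number from compound 2 to compound 3 (0.69 log units; beyond the scatter), and both bring in benzyloxy. The entering group in compound 4 has no ring, so no gain like an at least 5.0-fold lower number from compound 2 to compound 3 (0.69 log units; beyond the scatter) is expected. The expected outcome is a number no higher from compound 2 to compound 4 (the limit leaves the size open), with no readable change in this assay and quite possibly another limit. For compound 4 the estimated value is 100000 nM, with an expected range from 40000 nM to 200000 nM.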

Compound 4, half-maximal inhibitory concentration: > 100000 nM
Compound 4 ended at the assay's limit; the forecaster's own chance of this, stated with the estimate: 80%; the middle value lies on the limit itself.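

The result shows that adding a second hydroxy-bearing chain, with 2-hydroxyethyl in place of hydrogen on the amide-type nitrogen, brings no readable gain in this assay; the steps from compound 1 and compound 2 to compound 4 cannot be read, since both ends are limits. The one readable step is an at least 5.0-fold higher number from compound 3 to compound 4 (0.69 log units; beyond the scatter), so the benzyloxy group of compound 3 now stands apart from all three hydroxy-bearing groups shown. Compound 4 joins compound 1 and compound 2 at the same ceiling: the limit of > 100000 nM in this assay, at which 3 of the 4 values shown sit.

The limits leave open how far these three compounds differ from one another. As far as these compounds go, it also remains open whether the gain seen with compound 3 follows the phenyl ring or the oxygen on nitrogen, which a plain benzyl group or a methoxy group at this nitrogen could separate.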